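The source may hold more compounds than are shown below. What is called first, only, known or untested is meant among the compounds shown, and "the series" means these compounds.

Measured so far:
compound 1 `Cc1ccc(NC(=S)NC(=O)c2ccc(OCc3cccc(C(F)(F)F)c3)cc2)cc1-c1nc2ccccc2[nH]1` — 6050 nM
compound 2 `Cc1ccc(NC(=S)NC(=O)c2ccc(OCc3ccc(F)cc3)cc2)cc1-c1nc2ccccc2[nH]1` — 4220 nM
compound 3 `Cc1ccc(NC(=O)NC(=O)c2ccc(OCc3cccc(C(F)(F)F)c3)cc2)cc1-c1nc2ccccc2[nH]1` — 9600 nM

In a functional assay on MNK45 cells (Homo sapiens) for inhibition, read by MTT assay, with a stated time of 48 h (a higher number here means a weaker inhibitor, a lower number a stronger inhibitor), compound 3 gives the highest number of the three. Against compound 1 the gap is within the usual scatter of this assay, while against compound 2 the gap lies beyond it. Compound 4 `Cc1ccc(NC(=O)NC(=O)c2ccc(OCc3ccc(Cl)c(Cl)c3)cc2)cc1-c1nc2ccccc2[nH]1` differs from compound 3 in one place: 3,4-dichlorophenyl in place of 3-(trifluoromethyl)phenyl on a saturated chain carbon bound to an oxygen on an aromatic ring. The shared core and the urea linker of compound 3 are kept.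

Going by the values given here, only one measured step concerns a change at the same place, and it is a 1.4-fold lower number from compound 1 to compound 2 (0.16 log units; within the scatter), which carried the thiourea pair and a different aryl group, so it does not describe the present swap directly. Among the compounds with values here, no measured step concerns a dichlorophenyl group or a chlorine at all. Within the data shown here, what the single step does show is that exchanging the aryl group on that chain carbon left the number within the scatter, so no step beyond the scatter is expected in this assay for compound 4 either. The estimate for compound 4 is therefore 8000 nM, with a range from 3500 nM to 18000 nM, which means an expected step of a 1.2-fold lower number from compound 3 to compound 4 (0.08 log units; within the scatter).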

Compound 4, half-maximal inhibitory concentration: 5820 nM
For compound 4 the middle estimate is 1.4-fold (0.14 log units) above the measured one; the measured number falls inside the stated range.
By their numbers in this assay, from the lowest: compounds 2, 4, 1 and 3 (each within the scatter of the next, the first and the last beyond it).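

In this assay, going by these compounds alone, the exchange of 3-(trifluoromethyl)phenyl for 3,4-dichlorophenyl on a saturated chain carbon bound to an oxygen on an aromatic ring gives a 1.6-fold lower number from compound 3 to compound 4 (0.22 log units; within the scatter) and is the first reading of an aryl exchange at this place on the urea linker. Set beside a 1.4-fold lower number from compound 1 to compound 2 (0.16 log units; within the scatter) on the thiourea linker, it shows that two different aryl exchanges on two different linkers both stay within the scatter, so this place has so far shown no step beyond the scatter among the substituted phenyl groups present. Nothing measured here accounts for the size of either step.

It remains open whether 3,4-dichlorophenyl would read on the thiourea linker as it does on the urea linker, since the only aryl group shown on both linkers is 3-(trifluoromethyl)phenyl. As far as these compounds go, it is also open whether a phenyl ring carrying an amine or a carboxylic acid, or a longer chain in place of the benzyl group, would move the number in this assay beyond the scatter.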